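The source may hold more compounds than are shown below. What is called first, only, known or untested is meant among the compounds shown, and "the series" means these compounds.

Measured compounds in this series:
compound 1, `CCC(OC)C1=C(N2CC2)C(=O)C(C)=C(N2CC2)C1=O`, 5.33
compound 2, `CCC(COC(N)=O)C1=C(N2CC2)C(=O)C(C)=C(N2CC2)C1=O`, 5.66
compound 3, `CCC1=C(N2CC2)C(=O)C(CCOC(N)=O)=C(N2CC2)C1=O`, 5.48

In a functional assay on L1210 cells (Mus musculus), with a stated time of 12 days (on this read-out higher numbers stand for higher potency (the scale is a negative logarithm) and lower numbers for lower potency), compound 1 gives 5.33, the lowest of the three numbers. Compound 3, at 5.48, lies within the scatter of compound 1, so no order between these two can be read. Compound 2, at 5.66, lies beyond the scatter. Among the compounds with values here, the only single-point step among the measured compounds is a number 0.33 log units higher from compound 1 to compound 2 (beyond the scatter).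

Compound 4, `CC1=C(N2CC2)C(=O)C(C(C)C)=C(N2CC2)C1=O`, is not yet measured. isopropyl in place of 1-methoxypropyl on a double-bonded ring carbon

The step from compound 1 to compound 2 is the one that bears on this change, since it alters the same chain on the same ring carbon; it was modest in size. It does not, however, remove the oxygen-containing part of that chain, as the change to compound 4 does, so it serves only as a loose guide. Within the data shown here, no measured pair strips this chain down to a plain alkyl group. On that basis the expected step is small, in either direction or none beyond the scatter, with a wide range to cover the absence of a direct precedent: the estimated step is a number 0.03 log units lower from compound 1 to compound 4 (within the scatter). Compound 4 is therefore estimated at 5.3, with a range from 4.85 to 5.75.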

Compound 4, logarithm of the reciprocal of the active concentration, log(1/C): 5.21
Compound 4: the middle estimate sits 0.09 log units above what was measured, and the stated range covers the measured number.
By their numbers in this assay, from the lowest: compounds 4, 1, 3 and 2 (each within the scatter of the next, the first and the last beyond it).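

In this assay, within the data shown here, the step of a number 0.12 log units lower from compound 1 to compound 4 (within the scatter) is the first reading of a plain alkyl group on this double-bonded ring carbon, next to the ring atom that bears an aziridin-1-yl group. Among these compounds, earlier, the only step at this carbon kept an oxygen-containing chain, whereas here the methoxy oxygen and the hydrogen-bond acceptor it counts as both leave, the chain is shorter, and the number stays within the scatter, so at this level of resolution 1-methoxypropyl and isopropyl cannot be told apart on this read-out. Among the compounds shown here, the only step beyond the scatter at this carbon remains a number 0.33 log units higher from compound 1 to compound 2 (beyond the scatter), which brings in the (carbamoyloxy)methyl group, and nothing on hand gives a measured property that would account for either step.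

Open, on these data alone, is whether a longer plain chain such as n-hexyl at this carbon would also stay within the scatter of compound 1, or whether the number moves only once a group such as an amine or a carboxylic acid is carried on the chain. Also open, as far as these compounds go, is whether a carbamate placed on the isopropyl chain of compound 4 would give a step of the same size as the one seen from the 1-methoxypropyl chain.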